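Swapping Furan for Thiophene on a Cyclohexyl Ester

A few compounds are considered here, and "the series" means these few. Any claim that something is new, unique, unknown or untested is made for them only; others in the source may bear on it.

Of the compounds shown here, three sharing one core have been measured in an assay on membranes from HEK293 cells for displacement of a labelled ligand from adenosine receptor A2b (Homo sapiens), read by scintillation counting, with a stated time of 30 min, tested at 1 uM; on this read-out lower numbers stand for less inhibition and higher numbers for more inhibition at the one concentration tested (going by the name of the read-out). Compound 1 `CC1=C(C(=O)OCc2ccccc2)C(c2ccsc2)NC(=O)N1` carries a benzyl ester and a thiophen-3-yl group, and in this assay compound 1 gives 44%. Compound 2 `CC1=C(C(N)=O)C(c2ccsc2)NC(=O)N1` replaces the ester with a primary amide and in this assay compound 2 gives 1%. Compound 3 `CC1=C(C(=O)OC2CCCCC2)C(c2ccoc2)NC(=O)N1` carries a cyclohexyl ester and a furan-3-yl group, and in this assay compound 3 gives 4%. Among the three, compound 3 sits with compound 2 within the scatter, while compound 1 gives a higher number beyond the scatter.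

Compound 4 `CC1=C(C(=O)OC2CCCCC2)C(c2ccsc2)NC(=O)N1` differs from compound 3 in one place: thiophen-3-yl in place of furan-3-yl on a saturated ring carbon. Going by the values given here, no measured pair shows this particular exchange, so the only guide is that the thiophene-bearing compound 1 gives 44% while compound 3 gives 4%, with the ester also differing between them. An upward step is expected, estimated as a number 14 percentage points higher from compound 3 to compound 4 (beyond the scatter), of modest size and uncertain. For compound 4 the expected value in this assay is 18%, within a range from 0% to 45%.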

Compound 4, a percentage reported as inhibition, at one concentration (the size of the read-out at that concentration, not a potency): 4%
Estimate against measurement, compound 4: 14 percentage points above; low and high end bracket the measured number.
By their numbers in this assay, from the lowest: compounds 2, 3 and 4 (each within the scatter of the next); then compound 1.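

In this assay, putting thiophen-3-yl in place of furan-3-yl on the saturated ring carbon, with the cyclohexyl ester held fixed, gives no change at the digits printed from compound 3 to compound 4 (within the scatter), so with this ester the two rings cannot be told apart at this position. Compound 4 also shows how much the group on the carbonyl matters: cyclohexyl in place of benzyl on the oxygen gives a number 40 percentage points lower from compound 1 to compound 4 (beyond the scatter), while cyclohexyloxy in place of amino on the carbonyl carbon gives a number 3 percentage points higher from compound 2 to compound 4 (within the scatter), which places the cyclohexyl ester with the primary amide and not with the benzyl ester. Nothing available explains either result.

On these data alone, whether furan-3-yl would also match thiophen-3-yl on a benzyl ester, where the number is far higher, remains open. So does how a pyridin-3-yl group at this position, or a longer chain such as a phenethyl ester, would read in this assay.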